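Replacing the Aryl Group on the Saturated Ring

The source may hold more compounds than are shown below. What is called first, only, known or untested is meant among the compounds shown, and "the series" means these compounds.

Of the compounds shown here, three have so far been measured in an assay on HEK293 cells for antagonist activity at transient receptor potential M8 protein (Canis lupus familiaris), read by fluorescence and calcium flux, with a stated time of 5 min; a higher number here means a weaker inhibitor, a lower number a stronger inhibitor. Compound 2 `O=C(C(Nc1ccccc1F)c1ccc(C(F)(F)F)cc1)N1CCCC1c1cccc(F)c1` gives 9 nM, the lowest number of the three. Compound 1 `O=C(C(Nc1ccccc1)c1ccc(C(F)(F)F)cc1)N1CCC[C@H]1c1ccccc1Cl` gives 41 nM, and compound 3 `O=C(C(Nc1cccc(F)c1)c1ccc(C(F)(F)F)cc1)N1CCCC1c1ccccc1Cl` gives 138 nM. The gaps from compound 2 to compound 1 and to compound 3 both lie beyond the usual scatter, so compound 2 is the strongest inhibitor among the measured compounds.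

Compound 4 `COc1ccccc1C1CCCN1C(=O)C(Nc1ccccc1F)c1ccc(C(F)(F)F)cc1` has not yet been measured. It differs from compound 2 in a single place: 2-methoxyphenyl in place of 3-fluorophenyl on a saturated ring carbon. Among the measured compounds shown here, no measured pair of compounds differs only in this way, so the size of this step cannot be read from the numbers at hand. Compound 1 and compound 3 each carry a different group on that saturated ring carbon, but each also differs from compound 2 in the aniline part, so neither isolates the change in question.

With nothing in the data that points to a gain, a modest loss beyond the scatter is expected for the step of a 2.8-fold higher number from compound 2 to compound 4 (0.44 log units; beyond the scatter) in this assay. Compound 4 is therefore estimated to give 25 nM, with a plausible range from 6 nM to 100 nM.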

Compound 4, half-maximal inhibitory concentration: 12 nM
For compound 4 the middle estimate is 2.1-fold (0.32 log units) above the measured one; measured number inside the range.
By their numbers in this assay, from the lowest: compounds 2 and 4 (each within the scatter of the next); then compound 1; then compound 3.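

Among the compounds shown here, compound 2 and compound 4 form the first pair here that differs only on the saturated ring carbon, so the effect of changing the aryl group at this position can now be read directly in this assay: a 1.3-fold higher number from compound 2 to compound 4 (0.12 log units; within the scatter). On this shared core, then, 2-methoxyphenyl can stand in place of 3-fluorophenyl without a change that can be told apart from the usual scatter, even though the entering group carries a hydrogen-bond acceptor that the leaving group lacks and the two groups hold different substituents on the aromatic ring. Nothing at hand accounts for how closely the two numbers agree.

For the compounds shown here, this single pair covers only two substituted phenyl groups with the rest of the molecule held fixed, so it sets no general rule for the position and does not show how far the position's tolerance extends. Still open, on these data alone, is how the number would respond to a group of a different kind on this carbon, such as a pyridine ring, a cyclohexyl ring, or a phenyl ring carrying a carboxylic acid or an amine.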